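Swapping the amine tail of compound 1 for a pyridine ring

This account rests on a few compounds, and the source may have more. Where it says the series, first, only, none or still open, it means among the compounds named here.

Of the compounds shown here, three sharing one core have been measured in an assay on membranes from brain for inhibition of sphingomyelin phosphodiesterase 2 (Rattus norvegicus), using microsomes; a higher number here means a weaker inhibitor, a lower number a stronger inhibitor. Compound 1 `CCCCCCCCCCCCC/C=C/[C@@H](O)[C@H](COC(=O)NCCN(C)C)NC(=O)C(C)(C)C` gives 4100 nM, the lowest of the three numbers and so the strongest inhibitor among them. Compound 2 `CCCCCCCCCCCCC/C=C/[C@@H](O)[C@H](COC(=O)NCCN(C(C)C)C(C)C)NC(=O)C(C)(C)C` gives 18000 nM, and compound 3 `CCCCCCCCCCCCC/C=C/[C@@H](O)[C@H](COC(=O)NCCC(C)(C)C)NC(=O)C(C)(C)C` gives 77000 nM. The step of a 4.4-fold higher number from compound 1 to compound 2 (0.64 log units; beyond the scatter) shows a modest loss, the step of a 19-fold higher number from compound 1 to compound 3 (1.27 log units; beyond the scatter) a large one, and the step of a 4.3-fold higher number from compound 2 to compound 3 (0.63 log units; beyond the scatter) again a modest loss. Both changes that replaced the dimethylamino group of compound 1 therefore raised the number, and the change that removed the nitrogen altogether raised it most.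

Compound 4 `CCCCCCCCCCCCC/C=C/[C@@H](O)[C@H](COC(=O)NCc1cccnc1)NC(=O)C(C)(C)C` has not yet been measured. Relative to compound 1 the change is pyridin-3-yl in place of (dimethylamino)methyl on a saturated chain carbon bound to an amide-type nitrogen. Among the compounds with values here, no measured step covers exactly this swap, but the two steps away from compound 1 both point the same way: every replacement of the dimethylamino group so far has weakened inhibition, modestly when a nitrogen remained and strongly when it did not. The ring that enters still carries one hydrogen-bond acceptor, so a loss between those two outcomes is expected. Compound 4 is therefore estimated at 20000 nM, with a likely range from 6000 nM to 70000 nM, which would mean a step of a 4.9-fold higher number from compound 1 to compound 4 (0.69 log units; beyond the scatter).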

Compound 4, half-maximal inhibitory concentration: 2100 nM
Estimate against measurement, compound 4: 9.5-fold (0.98 log units) above; measured number outside the range, below it.
By their numbers in this assay, from the lowest: compounds 4 and 1 (each within the scatter of the next); then compound 2; then compound 3.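

In this assay the pyridin-3-yl group holds up as well as the dimethylamino tail, with a 2.0-fold lower number from compound 1 to compound 4 (0.29 log units; within the scatter), so these two compounds cannot be told apart. Compound 4 therefore goes against the earlier pattern, in which every replacement of the dimethylamino group raised the number, and it shows that a ring can stand on this saturated chain carbon bound to an amide-type nitrogen without a measurable loss. The same ring is clearly better than the other two tails, with an 8.6-fold lower number from compound 2 to compound 4 (0.93 log units; beyond the scatter) and a 37-fold lower number from compound 3 to compound 4 (1.56 log units; beyond the scatter), and since compound 2 also keeps a nitrogen in its tail, having a nitrogen there does not by itself settle the number.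

Nothing shown here explains why the ring matches the dimethylamino tail. On these data alone, a plain phenyl ring in the same place would show whether the ring nitrogen matters at all, and pyridin-4-yl or pyridin-2-yl would show whether its place in the ring matters, so both questions remain open.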